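A few compounds are considered here, and "the series" means these few. Any claim that something is new, unique, unknown or untested is made for them only; others in the source may bear on it.

Three compounds built on the same chlorinated aryloxyacetic acid carrying an alkyne were taken into an ADME assay on a cell-free system (plasma, Homo sapiens); a lower number here means a smaller unbound share, a higher number a larger unbound share of the compound. In this assay, compound 1 (`CCCS(=O)(=O)c1cccc(C#Cc2cc(Cl)ccc2OCC(=O)O)c1`) gives 0.008. For compound 2 (`CC(C)S(=O)(=O)c1ccc(Cl)c(C#Cc2cc(Cl)ccc2OCC(=O)O)c1`), the entry reads "not determined" (no result reported), so it offers no number to compare. Compound 3 (`CC(C)c1ccc(S(C)(=O)=O)cc1C#Cc1cc(Cl)ccc1OCC(=O)O`) gives 0.003, the lower of the two numbers available, and its gap to compound 1 lies beyond the usual scatter. Going by the values given here, compound 3 therefore has the smallest unbound share measured so far, although that ranking rests on only two values.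

The next compound is compound 4 (`Cc1ccc(S(C)(=O)=O)cc1C#Cc1cc(Cl)ccc1OCC(=O)O`), which has methyl in place of isopropyl on an aromatic carbon. The site is on a six-membered aromatic ring of carbon only, ortho to a large group and para to a methylsulfonyl group. Among the compounds with values here, no two measured compounds differ in one place only, so the data offer no direct precedent for this change. The expectation is therefore a modest rise in this assay, around the edge of the usual scatter, and no more than that. The estimated change is a 2.0-fold higher number from compound 3 to compound 4 (0.30 log units; within the scatter). For compound 4, the expected value is 0.006, with an estimated range from 0.003 to 0.012.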

Compound 4, unbound fraction: 0.017
Estimate against measurement, compound 4: 2.8-fold (0.45 log units) below; the measured number lies above the stated range.
By their numbers in this assay, from the lowest: compound 3; then compound 1; then compound 4.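

In this assay, going by these compounds alone, replacing isopropyl with methyl on an aromatic carbon, ortho to a large group and para to a methylsulfonyl group, gives a 5.7-fold higher number from compound 3 to compound 4 (0.75 log units; beyond the scatter) and provides the first comparison here in which only one place differs. The step shows that the unbound share responds to the alkyl group at this site, with the smaller methyl giving the higher number, although this rests on a single pair of compounds. Nothing available accounts for the size or direction of this shift, which therefore remains unexplained.

The compounds shown leave open whether the number changes steadily with the size of the alkyl group or whether isopropyl and methyl are simply two isolated cases, and an ethyl, a methoxy or an amine on the same carbon would test different aspects of that question. From the compounds shown here alone, it also remains open whether the same exchange would produce a step of similar size with a longer chain in place of the methyl on the sulfonyl group.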